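This account rests on a few compounds, and the source may have more. Where it says the series, first, only, none or still open, it means among the compounds named here.

Values in a functional assay on NCI-H460 cells (Homo sapiens) for antiproliferative activity, read by sulforhodamine B assay, with a stated time of 48 h; a lower number here means a stronger inhibitor of growth, a higher number a weaker inhibitor of growth:
- compound 1 `CCCCCCCCCCCCCCCCCC(=O)N1CCOCC1`: 53.1 ug/mL
- compound 2 `CCCCCCCC/C=C\CCCCCCCC(=O)N1CCCC1`: 45.6 ug/mL
- compound 3 `CCCCC/C=C\C/C=C\CCCCCCCC(=O)N1CCCCC1`: 29.1 ug/mL

Compound 2, at 45.6 ug/mL, lies within the scatter of both compound 1 and compound 3, so it stands apart from neither.

The next compound to be measured is compound 4 `CCCCCCCC/C=C\CCCCCCCC(=O)N1CCOCC1`. Its change from compound 2 is morpholin-4-yl in place of pyrrolidin-1-yl on a carbonyl carbon. In words, morpholin-4-yl takes the place of pyrrolidin-1-yl on a carbonyl carbon.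

Within the data shown here, no two measured compounds differ in one place, so the size of this change has no direct precedent. Compound 1 also carries morpholin-4-yl, on a different chain, and gives 53.1 ug/mL, which offers no sign of a large shift. No step beyond the scatter is expected in this assay, in either direction. The expected step is a 1.1-fold higher number from compound 2 to compound 4 (0.02 log units; within the scatter).

For compound 4 the estimated value is 48 ug/mL, with an expected range of 28 ug/mL to 80 ug/mL.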

Compound 4, concentration for 50% growth inhibition: 7.9 ug/mL
The estimate for compound 4 lay 6.1-fold (0.78 log units) above the measured number, outside the stated range (below it).
By their numbers in this assay, from the lowest: compound 4; then compounds 3, 2 and 1 (each within the scatter of the next).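

In this assay, among these compounds, the group on the carbonyl carbon matters on this chain: morpholin-4-yl in place of pyrrolidin-1-yl gives a 5.8-fold lower number from compound 2 to compound 4 (0.76 log units; beyond the scatter), the only step that can be read and one beyond the scatter. Compound 1, which also carries morpholin-4-yl but on a different chain, gives 53.1 ug/mL, so morpholin-4-yl does not go with a low number on every chain shown. No measurement offered here accounts for the step.

As far as these compounds go, it remains open whether thiomorpholin-4-yl or piperazin-1-yl on the chain of compound 2 would keep the lower number, which would test how much depends on the ring oxygen of morpholin-4-yl. Also open, from the compounds shown here alone, is whether the same exchange would give a step of similar size on the chains of compound 1 and compound 3.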